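A few compounds are considered here, and "the series" means these few. Any claim that something is new, unique, unknown or untested is made for them only; others in the source may bear on it.

Series notes. Compound 3 `C/C(=C\c1ccc(C(=O)Oc2ccc(C(=N)N)cc2)cc1)C(=O)N(CC(=O)O)C1CCCCC1` in an in vitro ADME assay on a cell-free system (plasma) for pharmacokinetics (on this read-out lower numbers stand for a shorter-lived compound and higher numbers for a longer-lived compound), gives > 1 h, which is a limit of the assay and not a number (the limit of > 1 h in this assay, at which 1 of the 3 values shown sits). Compound 4 `CCOC(=O)CN(C(=O)/C(C)=C/c1ccc(C(=O)Oc2ccc(C(=N)N)cc2)cc1)C1CCCCC1` differs from compound 3 by ethyl in place of hydrogen on an oxygen next to a carbonyl group. For the measured compounds named here, no measured pair isolates this change. Compound 1 `CCOC(=O)CN(C(=O)/C(C)=C/c1ccc(C(=O)Oc2ccc(C(=N)N)cc2)cc1)C1CCCC1` in this assay gives < 0.0834 h, again a limit (the limit of < 0.0834 h in this assay, at which 1 of the 3 values shown sits). Compound 2 `CCOC(=O)CN(Cc1ccccc1)C(=O)/C(C)=C/c1ccc(C(=O)Oc2ccc(C(=N)N)cc2)cc1` in this assay gives < 0.0167 h, also a limit (the limit of < 0.0167 h in this assay, at which 1 of the 3 values shown sits). Going by the values given here, the only measured step, a step that the two limits leave unreadable from compound 1 to compound 2, concerns another place and its size is not readable. Compounds 1 and 2 both carry the ethoxycarbonyl group and both read short, while compound 3 carries the carboxy group and reads long; compound 4 carries the ethoxycarbonyl group. The step of an at least 20-fold lower number from compound 3 to compound 4 (1.30 log units; beyond the scatter) is therefore expected to run toward shorter values. Compound 4 is estimated at 0.05 h, within 0.01 h to 0.3 h.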

Compound 4, half-life: < 0.0834 h
Compound 4 gave a limit, no number; the forecaster's own chance of this, stated with the estimate: 70%; the middle value lies beyond the limit too.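

In this assay, the change from carboxy to ethoxycarbonyl now has a matched pair with the cyclohexyl group held fixed: an at least 11-fold lower number from compound 3 to compound 4 (1.07 log units; beyond the scatter). Both ends of this step are limits of the assay and not numbers, so only its direction and minimum size are fixed. All three ethoxycarbonyl compounds shown now sit at short limits, and the steps among them on the amide-type nitrogen cannot be read.

Going by these compounds, whether carboxy analogues of compounds 1 and 2 also read long remains open. So does the reading of a methoxycarbonyl group or a primary carboxamide at this place.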